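The source may report more compounds than this note shows. Statements on the series, on what has been measured and on what is new or still open speak of the compounds shown alone.

Working notes on the series. Compound 1 `CCCCCCCCCCc1ccc(-c2noc(CCCN(C)C)n2)cc1` gives 8% in an assay on HeLa cells for inhibition of sphingosine-1-phosphate transporter SPNS2 (Mus musculus), read by LC-MS, tested at 2 uM; on this read-out lower numbers stand for less inhibition and higher numbers for more inhibition at the one concentration tested (going by the name of the read-out). Compound 2 `CCCCCCCCCCc1ccc(-c2noc([C@@H](N)CCCN)n2)cc1` gives 40%, and compound 3 `CCCCCCCCCCc1ccc(-c2noc([C@@H](N)CCCCN)n2)cc1` gives 43%. The steps are a number 32 percentage points higher from compound 1 to compound 2 (beyond the scatter) and a number 35 percentage points higher from compound 1 to compound 3 (beyond the scatter), both large, while a number 3 percentage points higher from compound 2 to compound 3 (within the scatter) stays within the scatter. Compound 3 therefore carries the highest of the three numbers, though it cannot be set apart from compound 2; only its gap to compound 1 is beyond the scatter.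

Compound 4 `CCCCCCCCCCc1ccc(-c2noc(CC(O)CN3CCCCC3)n2)cc1` has not been measured. Relative to compound 3 the change is 2-hydroxy-3-(piperidin-1-yl)propyl in place of 1,5-diaminopentyl on an aromatic carbon. The leaving 1,5-diaminopentyl carries 2 hydrogen-bond donors; the entering 2-hydroxy-3-(piperidin-1-yl)propyl carries 1 hydrogen-bond donor and one six-membered non-aromatic ring with 1 hetero atom. Among the measured compounds shown here, the steps that bear on this are those from compound 1, where exchanging 3-(dimethylamino)propyl for a diamine chain raised inhibition strongly; compound 4 moves back toward a chain without that second amine, so a step downward from compound 3, beyond the scatter, is expected, with the number likely settling between those of compound 1 and compound 3. The expected step is a number 25 percentage points lower from compound 3 to compound 4 (beyond the scatter). For compound 4 the estimate in this assay is 18%, ranging from 3% to 40%.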

Compound 4, a percentage reported as inhibition, at one concentration (the size of the read-out at that concentration, not a potency): 2%
For compound 4 the middle estimate is 16 percentage points above the measured one; the measured number lies below the stated range.
By their numbers in this assay, from the lowest: compounds 4 and 1 (each within the scatter of the next); then compounds 2 and 3 (each within the scatter of the next).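

In this assay, placing 2-hydroxy-3-(piperidin-1-yl)propyl on the aromatic carbon next to the ring oxygen gives a number 41 percentage points lower from compound 3 to compound 4 (beyond the scatter) and a number 38 percentage points lower from compound 2 to compound 4 (beyond the scatter), both large, so the gain seen with the two diamine chains does not carry over to this amino alcohol chain. The other comparison, a number 6 percentage points lower from compound 1 to compound 4 (within the scatter), stays within the scatter, showing that the hydroxyl and the piperidine ring do not set this compound apart from the dimethylamino chain of compound 1. Across these four compounds, the two diamine chains stand apart from the two chains ending in a tertiary amine, with no compound against that split, but no measurement at hand accounts for it.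

The step from compound 3 to compound 4 changes the chain length, the amine type, the hydroxyl and the ring at once, so what the compounds shown leave open is which of these matters. Also open, from the compounds shown here alone, is how the same position would read with a guanidine or a carboxylic acid at the chain end, or with a primary amine on a piperidine ring.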